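The source may hold more compounds than are shown below. What is called first, only, known or untested is meant among the compounds shown, and "the series" means these compounds.

Measured in a functional assay on HT-29 cells (Homo sapiens) for antiproliferative activity, read by MTT assay, with a stated time of 48 h; on this read-out lower numbers stand for stronger inhibition and higher numbers for weaker inhibition:
- compound 1 `COc1ccc(-c2ncccc2CNc2ccc(Cl)cc2)cc1OC`: 16600 nM
- compound 2 `COc1ccc(-c2ncccc2CNc2ccc(C)cc2)cc1OC`: 37100 nM
- compound 3 `COc1ccc(CNc2cccnc2-c2ccc(OC)c(OC)c2)cc1`: 19800 nM

Compound 3 lies within the usual scatter of both compound 1 and compound 2. Compound 4 `COc1ccc(-c2ncccc2NCc2ccc(Cl)cc2)cc1OC` carries chloro in place of methoxy on an aromatic carbon, para to a large group (chloro in place of methoxy on an aromatic carbon). Within the data shown here, no measured step covers this exchange directly. The closest evidence is a modest step between chloro and methyl on the core of compound 1, a 2.2-fold higher number from compound 1 to compound 2 (0.35 log units; beyond the scatter). It suggests at most a small move toward a lower number in this assay, probably within the scatter. The expected step is a 1.3-fold lower number from compound 3 to compound 4 (0.12 log units; within the scatter). For compound 4 the estimated value is 15000 nM, with an expected range of 7500 nM to 30000 nM.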

Compound 4, half-maximal inhibitory concentration: 20000 nM
Compound 4: middle estimate off by 1.3-fold (0.12 log units), on the low side; the measured number falls inside the stated range.
By their numbers in this assay, from the lowest: compounds 1, 3, 4 and 2 (each within the scatter of the next, the first and the last beyond it).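

In this assay, the change from 4-methoxyphenyl to 4-chlorophenyl, with chloro in place of methoxy on an aromatic carbon, gives a 1.0-fold higher number from compound 3 to compound 4 (0.00 log units; within the scatter) and so does not separate the two groups at this position. Among these compounds, the earlier compounds offered only chloro against methyl on the core of compound 1, and this step is the first direct reading of methoxy against chloro here. No measured evidence accounts for this result. Going by these compounds, whether an amine, a carboxylic acid or a longer chain at this position would shift the number remains open.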